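Methylpyridinyl regioisomers on the shared core

This account rests on a few compounds, and the source may have more. Where it says the series, first, only, none or still open, it means among the compounds named here.

Compound 1 `O=C(c1ccccc1)N1CCn2nc(-c3ccncc3)cc2C1` gives 1290 nM in a functional assay on HEK293 cells for negative allosteric modulation of metabotropic glutamate receptor 5 (Homo sapiens), read by calcium flux, with a stated time of 20 min; a lower number here means a stronger inhibitor, a higher number a weaker inhibitor.
Compound 2 `Cc1cccnc1-c1cc2n(n1)CCN(C(=O)c1ccccc1)C2` reaches only the assay limit in this assay, reported as > 10000 nM.

Compound 2 therefore stands at the weak end of the two measured numbers; its value is a limit, not a number, and sits at the limit of > 10000 nM in this assay, at which 1 of the 2 values shown sits. Among the measured compounds shown here, the one measured step, an at least 7.7-fold higher number from compound 1 to compound 2 (0.88 log units; beyond the scatter), shows that 3-methylpyridin-2-yl in place of pyridin-4-yl loses activity in this assay to at least a modest extent.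

Compound 3 `Cc1ccnc(-c2cc3n(n2)CCN(C(=O)c2ccccc2)C3)c1` keeps the same atoms as compound 2, joined differently: 4-methylpyridin-2-yl in place of 3-methylpyridin-2-yl on an aromatic carbon. For the measured compounds named here, no measured step bears directly on moving the methyl within the pyridin-2-yl ring, so the only anchors are the limit of compound 2 and the value of compound 1. Compound 3 is expected to recover part of the gap, with the step of an at least 2.8-fold lower number from compound 2 to compound 3 (0.45 log units; beyond the scatter) in this assay estimated in the stronger direction. Compound 3 is estimated at 3500 nM, within 800 nM to 10000 nM.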

Compound 3, half-maximal inhibitory concentration: 451 nM
The estimate for compound 3 lay 7.8-fold (0.89 log units) above the measured number; measured number below the stated range.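

Where the methyl sits on the pyridin-2-yl ring decides activity in this assay: moving it gives an at least 22-fold lower number from compound 2 to compound 3 (1.34 log units; beyond the scatter). Compound 2 stands at a limit of the assay, so the size of this step is only a lower bound: the limit of > 10000 nM in this assay, at which 1 of the 3 values shown sits.

The loss seen earlier therefore does not extend to every pyridin-2-yl ring at this position, as 4-methylpyridin-2-yl in place of pyridin-4-yl gives a 2.9-fold lower number from compound 1 to compound 3 (0.46 log units; beyond the scatter), a gain where 3-methylpyridin-2-yl gave a loss.

On these data alone, how much of that gain belongs to the methyl and how much to the pyridin-2-yl attachment stays open, as does the outcome with plain pyridin-2-yl, or with ethyl or methoxy in place of the methyl. As far as these compounds go, all three compounds also share the benzoyl group on the core, so whether the step carries over to a pyridine-3-carbonyl group there remains unknown.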